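The compounds below may be only part of what the source reports. "The series", "measured", "known", "first", "only" and "open" are said of these compounds alone.

Measured so far:
- compound 1 `COc1cc(O)c2c(c1)O[C@H](c1ccc(O)cc1)C/C2=N\NC(=O)OCc1ccccc1`: >= 11300 nM (a limit of the assay)
- compound 2 `COc1ccc([C@@H]2C/C(=N\Nc3ccccc3)c3c(O)cc(OC)cc3O2)cc1`: >= 11300 nM (a limit of the assay)
- compound 3 `COc1ccc([C@@H]2C/C(=N\NC(=O)c3ccc(N)cc3)c3c(O)cc(OC)cc3O2)cc1`: 3900 nM
- compound 4 `COc1ccc([C@@H]2C/C(=N\NC(=O)OCc3ccccc3)c3c(O)cc(OC)cc3O2)cc1`: not yet measured

Among the compounds with values here, in a functional assay on L5178Y cells (Mus musculus) for inhibition, read by MTT assay, with a stated time of 24 h (a higher number here means a weaker inhibitor, a lower number a stronger inhibitor), compound 3 gives 3900 nM and is the only compound with a true number so far. The next change goes from compound 3 to compound 4, with benzyloxy in place of 4-aminophenyl on a carbonyl carbon. Within the data shown here, only one measured step bears on this group: an at least 2.8-fold lower number from compound 2 to compound 3 (0.46 log units; beyond the scatter). That step, beyond the scatter, brought in (4-aminophenyl)carbonyl in place of phenyl on an amine nitrogen, and the 4-aminophenyl now leaves. Compound 1 also carries benzyloxy on a carbonyl carbon and sits at the limit of >= 11300 nM in this assay, at which 2 of the 3 values shown sit. A move towards a higher number, meaning a weaker inhibitor, is therefore expected, possibly as far as the limit. The expected size is a 2.1-fold higher number from compound 3 to compound 4 (0.31 log units; beyond the scatter). For compound 4 the estimate is 8000 nM, with an expected range of 3000 nM to 20000 nM.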

Compound 4, half-maximal inhibitory concentration: > 100000 nM
Compound 4 gave a limit, no number (the forecaster's own chance of this, stated with the estimate: 45%); middle value at least 12-fold (1.09 log units) away from the limit.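

In this assay, the carbonyl carbon on the amide-type nitrogen proves highly sensitive to its substituent: benzyloxy in place of 4-aminophenyl gives an at least 25-fold higher number from compound 3 to compound 4 (1.40 log units; beyond the scatter). Within the data shown here, compound 4 gives a limit of the assay, not a number: the limit of > 100000 nM in this assay, at which 1 of the 4 values shown sits. Compound 3 therefore remains the only compound with a true number, so (4-aminophenyl)carbonyl is the only group on this nitrogen with a readable value, and the steps to compound 4 from compound 2 and compound 1 cannot be read.

The compounds shown leave open whether the readable value depends on the amine of the 4-aminophenyl group or on an aromatic ring joined directly to the carbonyl carbon. A plain phenyl, or a hydroxyl or carboxylic acid in place of that amine, would separate these two readings.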